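A few compounds are considered here, and "the series" means these few. Any claim that something is new, unique, unknown or untested is made for them only; others in the source may bear on it.

Series notes.

Compound 1 `COc1ccc(-c2cnc(NC(=O)c3ccccc3F)n2C)cc1`: in a toxicity assay on THP-1 cells (Homo sapiens) for inhibition (a lower number here means that less compound is tolerated, a higher number that more compound is tolerated), compound 1 gives > 100000 nM, which is a limit of the assay.
Compound 2 `COc1ccc(-c2cnc(NC(=O)c3ccc(Br)cc3)n2C)cc1`: compound 2 gives > 100000 nM, likewise a limit.
Compound 3 `COc1ccc(-c2cnc(NC(=O)c3ccccc3C#N)n2C)cc1`: compound 3 gives > 100000 nM, again a limit.

Compound 3 therefore stands only at the limit; the limit of > 100000 nM in this assay, at which 3 of the 3 values shown sit, covers every value shown. No measured step can be read in size: a step that the two limits leave unreadable from compound 1 to compound 2, a step that the two limits leave unreadable from compound 1 to compound 3, a step that the two limits leave unreadable from compound 2 to compound 3. Compound 4 `COc1ccc(-c2cnc(NC(=O)C3CCNCC3)n2C)cc1` differs from compound 3 by piperidin-4-yl in place of 2-cyanophenyl on a carbonyl carbon. Going by the values given here, none of the measured steps bears on this change with a readable size, so no direction beyond the scatter can be expected in this assay. Because all three values sit at the limit (the limit of > 100000 nM in this assay, at which 3 of the 3 values shown sit), compound 4 is expected to remain near it, the estimated step being a number no higher from compound 3 to compound 4 (the limit leaves the size open). Compound 4 is estimated at 100000 nM, within 50000 nM to 300000 nM.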

Compound 4, half-maximal cytotoxic concentration: > 100000 nM
Compound 4: no number, only a limit; the forecaster's own chance of this, stated with the estimate: 85%; the middle value sits exactly at the limit.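

Compound 4 sits at a limit in this assay, so its steps from compound 1, compound 2 and compound 3 cannot be read in size: the limit of > 100000 nM in this assay, at which 4 of the 4 values shown sit.

The compounds shown leave open where any actual half-maximal cytotoxic concentration lies, and whether any group on the carbonyl carbon changes it.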